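This account rests on a few compounds, and the source may have more. Where it says the series, first, only, none or still open, it means among the compounds named here.

Working notes on the cyclohexyl urea series.

Compound 2 `O=C(Nc1ccccc1[N+](=O)[O-])N[C@H]1CC[C@H](Oc2ccc(F)cc2)CC1` is one of two compounds in the set that return a number in a functional assay on CRL2813 cells (Homo sapiens) for cytotoxicity, read by sulforhodamine B assay, with a stated time of 5 days (a lower number here means a stronger inhibitor, a higher number a weaker inhibitor), where compound 2 gives 3500 nM. Compound 3 `O=C(Nc1cccc(C(F)(F)F)c1)N[C@H]1CCC[C@H](Oc2ccc(C(F)(F)F)cc2)C1` gives 3800 nM in this assay, and its value and that of compound 2 sit within the scatter of each other, so no order can be read between them. Compound 1 `O=C(Nc1cccc(C(F)(F)F)c1)N[C@H]1CC[C@H](O)CC1` is different: in this assay compound 1 returns only a limit, > 20000 nM, and the limit of > 20000 nM in this assay, at which 1 of the 3 values shown sits, is the relevant fact about that value, not a number to be weighed against the others.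

Compound 4 `O=C(Nc1ccccc1Br)N[C@H]1CC[C@H](Oc2ccc(F)cc2)CC1` has not yet been measured in this assay. It differs from compound 2 in one place: bromo in place of nitro on an aromatic carbon, read one bond further out as 2-nitrophenyl to 2-bromophenyl. For the measured compounds named here, no pair of measured compounds in the set shows this change, so there is no measured step to lean on.

The expectation for compound 4 is therefore anchored on compound 2 and its value of 3500 nM, with a step of a 1.1-fold higher number from compound 2 to compound 4 (0.06 log units; within the scatter) expected, which stays within the scatter. In this assay compound 4 is estimated at 4000 nM, with a range from 1500 nM to 12000 nM.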

Compound 4, half-maximal inhibitory concentration: 7700 nM
Compound 4: the middle estimate sits 1.9-fold (0.28 log units) below what was measured; the measured number falls inside the stated range.
By their numbers in this assay, from the lowest: compounds 2 and 3 (each within the scatter of the next); then compound 4. At a limit, above all of these: compound 1.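

The series now has its first measured one-place step: in this assay, bromo in place of nitro on an aromatic carbon, ortho to a large group, gives a 2.2-fold higher number from compound 2 to compound 4 (0.34 log units; beyond the scatter). For the compounds shown here, the substituent at this position therefore has a readable, though modest, effect on the number, with the 2-nitrophenyl compound on the lower side of the 2-nitrophenyl to 2-bromophenyl change; the earlier compounds differed in more than one place and could not show this. Nothing shown bears on why the number moves in this direction.

From the compounds shown here alone, what a methoxy group, a nitrile or an amine on the same aromatic carbon would give stays open, and so does whether such groups would fall with compound 2 or with compound 4 in this assay. Going by these compounds, this is a single pair on a single core, so it also remains open whether the same change gives a similar step on the core of compound 3, with its trifluoromethyl groups.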